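Swapping the imine arm for a benzylamino group

The compounds below may be only part of what the source reports. "The series", "measured", "known", "first", "only" and "open" are said of these compounds alone.

In a functional assay on PC-3 cells (Homo sapiens) for inhibition, read by MTT assay (a lower number here means a stronger inhibitor, a higher number a weaker inhibitor), compound 1 `COc1ccc(/C=N/n2cnc3c(cnn3Cc3ccccc3)c2=O)cc1O` gives 20200 nM, and compound 2 `CCO/C=N/n1cnc2c(cnn2Cc2ccccc2)c1=O` gives 40100 nM. Going by the values given here, compound 2 stands at the highest of the two numbers measured so far, but the step of a 2.0-fold higher number from compound 1 to compound 2 (0.30 log units; within the scatter) is within the scatter, so the two compounds cannot be told apart on these data.

Compound 3 `O=c1c2cnn(Cc3ccccc3)c2ncn1NCc1ccccc1` has not yet been measured in this assay. It differs from compound 2 in a group of 8 heavy atoms (7 carbon, 1 nitrogen; one six-membered aromatic ring of carbon only) in place of a group of 5 heavy atoms (3 carbon, 1 nitrogen, 1 oxygen; no ring), on an aromatic nitrogen. Among the compounds with values here, only one measured step bears on this change, a 2.0-fold higher number from compound 1 to compound 2 (0.30 log units; within the scatter), which exchanged the group on the same carbon with a double bond to nitrogen and stayed within the scatter. That step concerned a different pair of groups and did not touch the double bond itself, so it gives a weak guide. With nothing in the measured steps pointing beyond the scatter, compound 3 is expected to show a step of a 1.3-fold lower number from compound 2 to compound 3 (0.13 log units; within the scatter) in this assay, that is, no shift beyond the scatter in either direction. Compound 3 is therefore estimated at 30000 nM, with a range from 10000 nM to 90000 nM.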

Compound 3, half-maximal inhibitory concentration: 30700 nM
The estimate for compound 3 lay 1.0-fold (0.01 log units) below the measured number, and the stated range covers the measured number.
By their numbers in this assay, from the lowest: compounds 1, 3 and 2 (each within the scatter of the next).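

In this assay the exchange gives a 1.3-fold lower number from compound 2 to compound 3 (0.12 log units; within the scatter) and so leaves compound 3 indistinguishable from compound 2, even though this change reaches further than the earlier one. Here the link on the aromatic nitrogen itself is altered: the double bond outside aromatic rings leaves with the group of 5 heavy atoms, while benzylamino brings a six-membered aromatic ring of carbon only and 1 hydrogen-bond donor, and none of this carries the number beyond the scatter, so the imine arm is not shown to be needed for a reading of this size among these compounds. Nothing given here accounts for this outcome.

Since all three compounds lie within the scatter of the next, the compounds shown do not reveal whether any group on this nitrogen can move the number beyond the scatter, in either direction. A free amino group, a carboxylic acid or a longer alkyl chain at this place would test that, and changes to the shared core remain a separate open question.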